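A few compounds are considered here, and "the series" means these few. Any claim that something is new, unique, unknown or untested is made for them only; others in the source may bear on it.

Measured so far:
Compound 1 `COc1ncnc2c1c(-c1cccs1)cn2[C@@H]1O[C@H](CO)[C@@H](O)[C@H]1O` — in a functional assay on K562 cells (Homo sapiens), read by MTT assay, with a stated time of 72 h (a higher number here means a weaker inhibitor, a lower number a stronger inhibitor), compound 1 gives 6200 nM.
Compound 2 `COc1nc(N)nc2c1c(-c1ccccc1)cn2[C@@H]1O[C@H](CO)[C@@H](O)[C@H]1O` — in this assay compound 2 gives > 20000 nM, a limit of the assay and not a number.
Compound 3 `COc1nc(N)nc2c1c(-c1ccco1)cn2[C@@H]1O[C@H](CO)[C@@H](O)[C@H]1O` — in this assay compound 3 gives > 20000 nM, also a limit and not a number.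

Compound 3 therefore stands at the limit, with no number of its own; compound 2 sits at the same limit. For the measured compounds named here, the one measured step, from compound 2 to compound 3, is a step that the two limits leave unreadable from compound 2 to compound 3, so it says nothing about the size of an aryl exchange on this position.

Compound 4 `COc1nc(N)nc2c1c(-c1cccs1)cn2[C@@H]1O[C@H](CO)[C@@H](O)[C@H]1O` is not yet measured. The change is thiophen-2-yl in place of furan-2-yl on an aromatic carbon. Going by the values given here, no measured step bears directly on this exchange. Compound 1 also carries thiophen-2-yl and gives a number, but it differs from compound 4 at another place, so only its value can be noted. Because (the limit of > 20000 nM in this assay, at which 2 of the 3 values shown sit), the step from compound 3 to compound 4 is expected to be a number no higher from compound 3 to compound 4 (the limit leaves the size open), with a limit the more likely outcome. Compound 4 is therefore estimated at 20000 nM, within 6000 nM to 60000 nM.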

Compound 4, half-maximal inhibitory concentration: > 20000 nM
Compound 4: only a limit was reported; the forecaster's own chance of this, stated with the estimate: 60%; the middle value sits exactly at the limit.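

The new comparison is the amino exchange with thiophen-2-yl held constant: in this assay the pair gives an at least 3.2-fold higher number from compound 1 to compound 4 (0.50 log units; beyond the scatter), so amino in place of hydrogen on an aromatic carbon goes with weaker inhibition, in this single pair only. The steps among compound 2, compound 3 and compound 4 cannot be read, and phenyl, furan-2-yl and thiophen-2-yl remain unranked on the amino-bearing core. The exchange of furan-2-yl for thiophen-2-yl therefore adds no size to the picture, and the series now rests largely on one assay limit: the limit of > 20000 nM in this assay, at which 3 of the 4 values shown sit.

From the compounds shown here alone, whether phenyl or furan-2-yl on the core of compound 1 would give values that differ from the thiophen-2-yl compound remains open. Also open, going by these compounds, is whether a smaller group at this position, such as methyl or a dimethylamino group, would bring the amino-bearing core to a readable number in this assay.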